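Swapping fluorine for methyl on the cyclopropyl amide

This account rests on a few compounds, and the source may have more. Where it says the series, first, only, none or still open, it means among the compounds named here.

Measured so far:
compound 1, `CC(C)C(=O)N1CC2CC(C1)N2` — 20000 nM
compound 2, `O=C([C@H]1C[C@@H]1F)N1CC2CC(C1)N2` — 2800 nM

Going by the values given here, in an assay on SH-EP1 cells for agonist activity at Neuronal acetylcholine receptor; alpha4/beta2 (Homo sapiens), read by FLIPR and calcium flux (on this read-out higher numbers stand for an effect only at larger amounts of compound and lower numbers for an effect already at smaller amounts), compound 2 gives the lowest of the two numbers; its nearest neighbour is compound 1, and the only measured step, a 7.1-fold lower number from compound 1 to compound 2 (0.85 log units; beyond the scatter), separates them. Compound 3, `C[C@@H]1C[C@H]1C(=O)N1CC2CC(C1)N2`, has not yet been measured. Its change from compound 2 is 2-methylcyclopropyl in place of 2-fluorocyclopropyl on a carbonyl carbon. Among the compounds with values here, no measured step replaces fluorine by methyl on a cyclopropyl ring, so nothing directly bears on it. Within the data shown here, the one step available, a 7.1-fold lower number from compound 1 to compound 2 (0.85 log units; beyond the scatter), joins two changes at once: an open chain becomes a three-membered ring, and fluorine arrives. Compound 3 keeps the ring and drops the fluorine, so its number in this assay is expected to sit between the two measured values, closer to compound 2 than to compound 1, given that compound 2 gives 2800 nM. Compound 3 is estimated at 5000 nM, with a range from 1500 nM to 17000 nM. The step of a 1.8-fold higher number from compound 2 to compound 3 (0.25 log units; within the scatter) is thus expected to be small to modest, towards a higher number.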

Compound 3, half-maximal effective concentration: 2900 nM
Compound 3: middle estimate off by 1.7-fold (0.24 log units), on the high side, within the range that was stated.
By their numbers in this assay, from the lowest: compounds 2 and 3 (each within the scatter of the next); then compound 1.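

In this assay, 2-methylcyclopropyl in place of 2-fluorocyclopropyl on a carbonyl carbon gives a 1.0-fold higher number from compound 2 to compound 3 (0.02 log units; within the scatter) and so, at this place, the two groups cannot be told apart by this read-out. The earlier comparison with the isopropyl amide could not separate the arrival of the ring from the arrival of fluorine, whereas 2-methylcyclopropyl in place of isopropyl gives a 6.9-fold lower number from compound 1 to compound 3 (0.84 log units; beyond the scatter) with no fluorine present, which shows that fluorine is not required for a lower number than that of compound 1. The measurements offer nothing that explains why the fluorine and methyl groups read alike here.

Going by these compounds, what the ring alone contributes stays open, since a plain unsubstituted cyclopropyl amide would be needed to separate it from the effect of the group the ring carries. On these data alone, it also remains unknown whether this tolerance extends to other groups on the ring, such as a hydroxyl, an amine or a trifluoromethyl, or to the opposite arrangement of the two stereocentres.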